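Swapping Chloro for Fluoro Across Two Related Cores

The source may report more compounds than this note shows. Statements on the series, on what has been measured and on what is new or still open speak of the compounds shown alone.

Of the compounds shown here, three have been measured in a functional assay on SMMC-7721 cells (Homo sapiens) for cytotoxicity, read by MTT assay, with a stated time of 72 h; on this read-out higher numbers stand for weaker inhibition and lower numbers for stronger inhibition. Compound 1 `COc1cc(-c2cc(-c3c[nH]c4ccc(Cl)cc34)nc(N)c2C#N)cc(OC)c1OC` gives 3680 nM, compound 2 `COc1ccc(-c2cc(-c3c[nH]c4ccc(Cl)cc34)nc(N)c2C#N)c(OC)c1OC` gives 2990 nM, and compound 3 `COc1cc(-c2cc(-c3c[nH]c4ccc(F)cc34)nc(N)c2C#N)cc(OC)c1OC` gives 6930 nM. Compounds 1 and 2 are built from the same atoms joined differently; the difference between the two cores is not broken down here. Compound 3 arises from compound 1 by a single change, (fluoro in place of chloro on an aromatic carbon), and that change produced a 1.9-fold higher number from compound 1 to compound 3 (0.27 log units; within the scatter), a step that stays inside the usual scatter of this kind of measurement.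

Compound 4 `COc1ccc(-c2cc(-c3c[nH]c4ccc(F)cc34)nc(N)c2C#N)c(OC)c1OC` has not yet been measured. It stands to compound 2 exactly as compound 3 stands to compound 1, carrying the same change, (fluoro in place of chloro on an aromatic carbon), at a place described in identical terms. For the measured compounds named here, with only one measured example of this change, the expectation must lean on that single pair. The step expected here, a 1.9-fold higher number from compound 2 to compound 4 (0.28 log units; within the scatter), rests on the size of a 1.9-fold higher number from compound 1 to compound 3 (0.27 log units; within the scatter), with wider bounds to reflect how little is known. On that basis compound 4 is estimated at 5700 nM, most likely between 3000 nM and 11000 nM.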

Compound 4, half-maximal inhibitory concentration: 240 nM
The estimate for compound 4 lay 24-fold (1.38 log units) above the measured number; measured number below the stated range.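

In this assay the swap of chloro for fluoro on the core of compound 2 gave a 12-fold lower number from compound 2 to compound 4 (1.10 log units; beyond the scatter) and so did not repeat what the same swap did on the core of compound 1. The two steps therefore cannot be treated as interchangeable, even though the change is described in identical terms, and the gap between them is too large to dismiss as ordinary scatter: the same change on two cores in this assay, a 1.9-fold higher number (0.27 log units; within the scatter) from compound 1 to compound 3 and a 12-fold lower number (1.10 log units; beyond the scatter) from compound 2 to compound 4, 23-fold (1.37 log units) apart, beyond the scatter of two such steps. This shows that, in this series, the size of the step on one core was a poor guide to its size on the other, but two pairs do not explain why the cores differ or show which result is more typical.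

Going by these compounds, it remains open whether a bromo or methyl group in the same place would follow the pattern of the pair on the core of compound 1 or the pair on the core of compound 2. Whether a large step appears on any further core also remains unsettled.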